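The compounds below may be only part of what the source reports. "The series", "measured", "known", "first", "only" and "open" are said of these compounds alone.

Compound 1 `FC(F)(F)c1ccc2[nH]c(-c3ccc(-c4nnc[nH]4)cc3)nc2c1` is the starting point of this account. In a functional assay for antagonist activity at Neuropeptides B/W receptor type 1 (Homo sapiens), read by cAMP accumulation (on this read-out lower numbers stand for stronger inhibition and higher numbers for weaker inhibition), compound 1 gives 3080 nM, the highest of the two numbers reported, and the nearest number belongs to compound 2 `Cc1ccc(-c2nc3cc([N+](=O)[O-])ccc3[nH]2)cc1C`, which gives 1380 nM, a gap that lies beyond the scatter. Compound 3 `CC(=O)c1cccc(-c2nc3cc([N+](=O)[O-])ccc3[nH]2)c1` yields only a limit, > 31600 nM; this is the limit of > 31600 nM in this assay, at which 1 of the 3 values shown sits. Compound 4 `FC(F)(F)c1ccc2[nH]c(-c3ccc(-c4ccoc4)cc3)nc2c1` has not yet been measured; it differs from compound 1 by furan-3-yl in place of 4H-1,2,4-triazol-3-yl on an aromatic carbon. Going by the values given here, no measured pair shows this change, so the expected step is small, with no direction claimed beyond the scatter, estimated as a 1.3-fold higher number from compound 1 to compound 4 (0.11 log units; within the scatter). Compound 4 is therefore expected to give 4000 nM, between 1000 nM and 16000 nM.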

Compound 4, half-maximal inhibitory concentration: 1190 nM
The estimate for compound 4 lay 3.4-fold (0.53 log units) above the measured number, within the range that was stated.
By their numbers in this assay, from the lowest: compounds 4 and 2 (each within the scatter of the next); then compound 1. At a limit, above all of these: compound 3.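

In this assay, the exchange at this position, on an aromatic carbon para to a large group, gives a 2.6-fold lower number from compound 1 to compound 4 (0.41 log units; beyond the scatter), the first single-place change shown among these compounds. Furan-3-yl carries no hydrogen-bond donor, so in this one pair the donor of 4H-1,2,4-triazol-3-yl is not needed to reach the lower number. Nothing measured here accounts for the size of this step. The compounds shown leave open how a carboxylic acid or a primary amine would read in the same place.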